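The compounds below may be only part of what the source reports. "The series", "measured", "known", "first", "only" and "open" are said of these compounds alone.

For the measured compounds named here, compound 1 `NS(=O)(=O)c1ccccc1-n1nc(C(F)(F)F)c2c1C(=O)N(c1ccc(-c3ccccc3CN3CC[C@@H](O)C3)cc1)CC2` is one of two compounds measured in an in vivo ADME assay on the whole organism for pharmacokinetics, with Canis familiaris (Canis lupus familiaris) as the target (a higher number here means that a larger share of the oral dose reaches the circulation, a lower number that a smaller share of the oral dose reaches the circulation), and it stands at the top of the pair: in this assay compound 1 gives 93%. Its companion, compound 2 `CN(C)Cc1ccccc1-c1ccc(N2CCc3c(C(F)(F)F)nn(-c4ccccc4S(N)(=O)=O)c3C2=O)cc1`, differs only where the basic amine sits on the saturated chain carbon bound to an aromatic carbon, and in this assay compound 2 gives 52%. That single measured step, a number 41 percentage points lower from compound 1 to compound 2 (beyond the scatter), shows how strongly a change at that far end of the molecule can move the read-out.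

Compound 3 `NC(=O)c1cccc(-n2nc(C(F)(F)F)c3c2C(=O)N(c2ccc(-c4ccccc4CN4CC[C@@H](O)C4)cc2)CC3)c1` takes a different route. Here the amine end stays as it is in compound 1, and the change is made at the other side of the shared core: 3-carbamoylphenyl in place of 2-sulfamoylphenyl on an aromatic nitrogen. Going by the values given here, no measured step touches this position; the one known step concerns the amine, not the aryl on the aromatic nitrogen, so it gives no direct guide to the direction or size of what follows. Compound 1 already sits high, leaving little room upward and much more room downward, and the outcome of the step to compound 3 in this assay is what remains to be learned.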

Compound 3, oral bioavailability: 72%
Compound 3: the middle estimate sits 2 percentage points below what was measured; the measured number falls inside the stated range.
By their numbers in this assay, from the lowest: compound 2; then compound 3; then compound 1.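

In this assay the aryl group on the aromatic nitrogen turns out to move the read-out as well, and not only the amine end at the far side of the molecule (a number 21 percentage points lower from compound 1 to compound 3 (beyond the scatter)). The change replaces 2-sulfamoylphenyl with 3-carbamoylphenyl, so the group on the phenyl ring and its place on that ring differ together, and this one step cannot divide the fall between the two. Nothing at hand accounts for the lower number at this position, so the step stands as an observation without an explanation.

Left open is where 2-carbamoylphenyl or 3-sulfamoylphenyl would land, since either would separate the group from its place on the ring and show which of the two carries the step. Also open, going by these compounds, is whether the same change would give a similar step with the dimethylamino end of compound 2, and how a carboxylic acid or a nitrile on that phenyl ring would read in this assay.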